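This account rests on a few compounds, and the source may have more. Where it says the series, first, only, none or still open, it means among the compounds named here.

Measured compounds in a functional assay on the whole organism (Tail, strain ICR) with Mus musculus as the target, in the tail flick test, with a stated time of 120 min, at a dose of 25 umol/kg by the oral route; on this read-out higher numbers stand for a stronger effect at the one dose given and lower numbers for a weaker effect:
compound 1 `O=C(CN(c1nc(Cl)nc2[nH]cnc12)C1CC1)N[C@@H](CO)C(=O)OCc1ccccc1` gives 34.5%
compound 2 `NC(=O)CC[C@H](NC(=O)CN(c1ncnc2c1ncn2C1CCCCO1)C1CC1)C(=O)OCc1ccccc1` gives 22.3%
compound 3 `C[C@@H](O)[C@H](NC(=O)CN(c1nc(Cl)nc2[nH]cnc12)C1CC1)C(=O)O` gives 37.6%

Compound 2 is the lowest of the three numbers; its nearest neighbour is compound 1, higher by an amount beyond the scatter, and compound 3 stands furthest, also higher beyond the scatter. Within the data shown here, no pair of measured compounds differs in only one place, so no measured step is at hand for this series.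

Compound 4 `O=C(CN(c1ncnc2c1ncn2C1CCCCO1)C1CC1)N[C@@H](CC(=O)OCc1ccccc1)C(=O)OCc1ccccc1` is not yet measured. It differs from compound 2 by benzyloxycarbonyl in place of carbamoylmethyl on a saturated chain carbon, two bonds along the chain from an amide-type nitrogen and a carbonyl carbon; cut one bond further out the same difference reads 2-carbamoylethyl to (benzyloxycarbonyl)methyl.

Among the measured compounds shown here, with no measured step to lean on, only a modest change is expected, if any beyond the scatter, in either direction. Compound 4 is expected to give 29% in this assay, within 12% to 46%. The step expected is a number 6.7 percentage points higher from compound 2 to compound 4 (within the scatter).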

Compound 4, a percentage reported as activity, at one dose (the size of the read-out at that dose, not a potency): 7.82%
The estimate for compound 4 lay 21.2 percentage points above the measured number; measured number outside the range, below it.
By their numbers in this assay, from the lowest: compound 4; then compound 2; then compounds 1 and 3 (each within the scatter of the next).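

In this assay, the series' only readable step runs a number 14.5 percentage points lower from compound 2 to compound 4 (beyond the scatter), which shows that the saturated chain carbon is sensitive to substitution: benzyloxycarbonyl in place of carbamoylmethyl goes with a weaker effect at the one dose given. Among these compounds, this change brings in a six-membered aromatic ring and removes a hydrogen-bond donor, and the single step cannot separate these two features. No measurement at hand speaks to the origin of this step.

Going by these compounds, it remains open whether a methyl ester or a primary amine in place of the benzyloxycarbonyl would retain the effect seen with compound 2.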